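The source may report more compounds than this note shows. Statements on the series, on what has been measured and on what is new or still open speak of the compounds shown alone.

Measured so far:
- compound 1 `Cc1ccnc(/C(N)=N/NC(=S)N2CCSCC2)c1` — 74.5%
- compound 2 `N/C(=N\NC(=S)N1CCSCC1)c1ccccn1` — 83.9%
- compound 3 `Cc1cccc(/C(N)=N/NC(=S)N2CCN(c3ccccn3)CC2)n1` — 63.3%

In a functional assay on A-375 cells (Homo sapiens) for cytotoxicity, read by MTT assay, with a stated time of 72 h, tested at 10 uM (on this read-out lower numbers stand for less inhibition of growth and higher numbers for more inhibition of growth at the one concentration tested), compound 2 gives 83.9%, the highest of the three numbers shown, though compound 1 lies within the usual scatter of it, while compound 3 sits beyond the scatter below it. Among the measured compounds shown here, the only step between two measured compounds that differ in one place is a number 9.4 percentage points higher from compound 1 to compound 2 (within the scatter), a change on an aromatic carbon that leaves the ring on the thiocarbonyl carbon untouched.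

Compound 4 `N/C(=N\NC(=S)N1CCCCC1)c1ccccn1` differs from compound 2 by piperidin-1-yl in place of thiomorpholin-4-yl on a thiocarbonyl carbon. For the measured compounds named here, no measured pair isolates this change: compound 3 carries a different ring at the same place but also differs elsewhere, so its value alone cannot be read as the effect of swapping that ring. Going by the values given here, with nothing among the measured steps bearing on the change, no step beyond the scatter is expected in this assay, and the expected step is a number 5.9 percentage points lower from compound 2 to compound 4 (within the scatter). Compound 4 is therefore estimated at 78%, with a range from 60% to 92%.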

Compound 4, percent growth inhibition at one concentration: 85.8%
For compound 4 the middle estimate is 7.8 percentage points below the measured one; low and high end bracket the measured number.
By their numbers in this assay, from the lowest: compound 3; then compounds 1, 2 and 4 (each within the scatter of the next, the first and the last beyond it).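

In this assay, the first direct test of the ring on the thiocarbonyl carbon gives a number 1.9 percentage points higher from compound 2 to compound 4 (within the scatter) and so stays inside the usual scatter. The earlier step concerned an aromatic carbon, whereas this pair shows that, at the one concentration tested, growth inhibition in this pair does not depend on the ring sulfur of thiomorpholin-4-yl, since piperidin-1-yl has carbon there and the two compounds cannot be told apart. Nothing available explains why these two rings read alike.

As far as these compounds go, it remains open how the read-out responds on the same thiocarbonyl carbon to morpholin-4-yl, which has oxygen in the ring, or to an open-chain group such as diethylamino. Whether any ring at this position can move the number beyond the scatter, with the rest of compound 2 kept the same, is also unresolved.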